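Turning the stereocentre of compound 3 around

The source may report more compounds than this note shows. Statements on the series, on what has been measured and on what is new or still open speak of the compounds shown alone.

Compound 3 `C[C@@H](C(=O)NCc1ccc(C(F)(F)F)cc1SC1CCCCC1)c1ccc(NS(C)(=O)=O)c(F)c1` holds the highest number of the three measured in an assay on CHO cells for antagonist activity at transient receptor potential cation channel subfamily V member 1 (Homo sapiens), read by FLIPR (a higher number here means a weaker inhibitor, a lower number a stronger inhibitor), giving 13.9 nM. Compound 1 `CC(C(=O)NCc1ccc(C(F)(F)F)cc1N1CCCCCCC1)c1ccc(NS(C)(=O)=O)c(F)c1` gives 2.8 nM and compound 2 `CC(C(=O)NCc1ccc(C(F)(F)F)cc1SC1CCCCC1)c1ccc(NS(C)(=O)=O)c(F)c1` gives 0.5 nM. The step of a 5.6-fold lower number from compound 1 to compound 2 (0.75 log units; beyond the scatter) trades an eight-membered ring with one hetero atom for a six-membered carbon ring on an aromatic carbon, while the step of a 28-fold higher number from compound 2 to compound 3 (1.44 log units; beyond the scatter) changes no atom or bond at all: it rests on the fact that (the fact that one of compounds 2 and 3 is drawn with a defined configuration and the other without, at the place where they differ), the stereocentre at the saturated chain carbon being drawn without configuration in compound 2 and as R in compound 3.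

Compound 4 `C[C@H](C(=O)NCc1ccc(C(F)(F)F)cc1SC1CCCCC1)c1ccc(NS(C)(=O)=O)c(F)c1` continues along that same axis: the two compounds have the same atoms and bonds and differ only in configuration as drawn: 1 of 1 stereo elements differ; a stereocentre at a saturated chain carbon is drawn R in compound 3 and S in compound 4. Among the measured compounds shown here, only the step from compound 2 to compound 3 bears on it, and that step was large. Since compound 2, drawn without configuration, gives 0.5 nM while compound 3, drawn R, gives 13.9 nM, the S form is expected to carry the stronger inhibition, and the step of a 46-fold lower number from compound 3 to compound 4 (1.67 log units; beyond the scatter) is therefore expected to be large and downward in this assay. Compound 4 is estimated at 0.3 nM, within a range from 0.1 nM to 1 nM.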

Compound 4, inhibition constant: 0.3 nM
Compound 4: the middle estimate sits on the measured number at the digits printed; low and high end bracket the measured number.
By their numbers in this assay, from the lowest: compounds 4 and 2 (each within the scatter of the next); then compound 1; then compound 3.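

In this assay, turning the one stereocentre at the saturated chain carbon from R to S gives a 46-fold lower number from compound 3 to compound 4 (1.67 log units; beyond the scatter), so the size of the effect now comes from two compounds that are both drawn with a defined configuration, which the earlier comparison could not offer: the fact that compounds 3 and 4 differ only in the configuration as drawn

The form drawn without a configuration and the form drawn S are not separated by this measurement, the step being a 1.7-fold lower number from compound 2 to compound 4 (0.22 log units; within the scatter): the fact that one of compounds 2 and 4 is drawn with a defined configuration and the other without, at the place where they differ

Taken together, these numbers place the R form alone apart from the other two at this centre, although that reading rests on this single pair of stereoisomers, which both carry the six-membered carbon ring on sulfur.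

The compounds shown leave open whether the same preference for S would hold with the eight-membered ring of compound 1 on the aromatic carbon. They also leave open how this position would respond if an ethyl group or a second methyl group stood on the saturated chain carbon, where a stereocentre would be changed or lost.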